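This account rests on a few compounds, and the source may have more. Where it says the series, first, only, none or still open, it means among the compounds named here.

Measured so far in an ADME assay on MT4 cells (Homo sapiens) for cytotoxicity, read by MTT assay, with a stated time of 3 days; a lower number here means that less compound is tolerated, a higher number that more compound is tolerated:
compound 1 `CC(C)OC(=O)COC(=O)c1ccc([N+](=O)[O-])o1`: > 100000 nM (a limit)
compound 2 `CC(C)(C)NC(=O)COC(=O)c1ccc([N+](=O)[O-])o1`: > 100000 nM (a limit)

Compound 2 stands on a limit only, not a number. For the measured compounds named here, the one further reading, for compound 1, is a limit too, so the series so far amounts to the limit of > 100000 nM in this assay, at which 2 of the 2 values shown sit.

Next is compound 3 `CCC(C)(C)NC(=O)COC(=O)c1ccc([N+](=O)[O-])o1`, with the change methyl in place of hydrogen on a saturated chain carbon, two bonds along the chain from an amide-type nitrogen: tert-butyl becomes 1,1-dimethylpropyl. Going by the values given here, the only measured step is a step that the two limits leave unreadable from compound 1 to compound 2. It concerns a different change and gives no size to carry over. In this assay, no shift beyond the scatter is therefore expected. This expectation rests on compound 2, whose reading is > 100000 nM, a limit. The expected step is a number no higher from compound 2 to compound 3 (the limit leaves the size open). For compound 3 the estimated value is 100000 nM, with an expected range of 40000 nM to 250000 nM.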

Compound 3, half-maximal cytotoxic concentration: > 100000 nM
Compound 3: only a limit was reported (the forecaster's own chance of this, stated with the estimate: 80%); the middle value lies on the limit itself.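

In this assay, for the compounds shown here, compound 3 gives > 100000 nM, a limit, so no step among compound 1, compound 2 and compound 3 can be read. The compounds shown leave open at what concentration any of them becomes cytotoxic, and whether any of the changes alters that concentration.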